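A few compounds are considered here, and "the series" means these few. Any claim that something is new, unique, unknown or untested is made for them only; others in the source may bear on it.

Compound 1 (`CS(=O)(=O)N1C(=O)COC12C=CC(=O)C=C2`) gives > 10000 nM in a functional assay on MDA-MB-231 cells (Homo sapiens) for inhibition, read by sulforhodamine B assay, with a stated time of 74 h (on this read-out lower numbers stand for stronger inhibition and higher numbers for weaker inhibition), as its read-out, and this is a limit, not a number. Compound 2 (`O=C1C=CC2(C=C1)OCC(=O)N2S(=O)(=O)c1cccc(C(F)(F)F)c1`) gives > 10000 nM in this assay as well, again a limit. Among the measured compounds shown here, the series therefore stands at the limit of > 10000 nM in this assay, at which 2 of the 2 values shown sit, for now, and no measured step is available to scale the next change. Compound 3 (`O=C1C=CC2(C=C1)OCC(=O)N2S(=O)(=O)c1ccc(Br)s1`) carries 5-bromothiophen-2-yl in place of methyl on a sulfonyl sulfur on the core of compound 1. In this assay a shift toward stronger inhibition of uncertain size is expected, and a result still at the limit would fit the data so far. The estimated at least 1.6-fold lower number from compound 1 to compound 3 (0.22 log units; that floor lies within the scatter) starts from a limit and remains loose for that reason. Compound 3 is estimated at 6000 nM with an expected range from 300 nM to 20000 nM in this series.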

Compound 3, half-maximal inhibitory concentration: > 10000 nM
Compound 3 was reported as a limit; the forecaster's own chance of this, stated with the estimate: 50%; at least 1.6-fold (0.22 log units) between middle value and limit.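

Among the compounds shown here, compound 1 and compound 3 both stand at a limit, so no step between them can be read, and the series stays where it was: the limit of > 10000 nM in this assay, at which 3 of the 3 values shown sit. In this assay the compounds shown leave open which group on the sulfonyl sulfur, if any, gives a value that is not a limit.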